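Solubility of compound 4 against three limit-bound analogues

The source may hold more compounds than are shown below. What is called first, only, known or untested is meant among the compounds shown, and "the series" means these compounds.

Compound 1 `COc1cccc(Nc2cc3[nH]c(-c4cccc(C(F)(F)F)c4)nc3cn2)n1` is one of three compounds built on a shared core that have been measured in a physicochemical assay for solubility, using the shake flask method, in phosphate buffer, measured as kinetic solubility, with a stated time of 20 h, at pH 6.5; a lower number here means a less soluble compound, a higher number a more soluble compound. In this assay compound 1 gives only a limit, < 5000 nM. Compound 2 `FC(F)(F)c1cccc(-c2nc3cnc(Nc4cnccn4)cc3[nH]2)c1` likewise gives only a limit in this assay, < 5000 nM. Compound 3 `Fc1cnc(Nc2cc3[nH]c(-c4cccc(C(F)(F)F)c4)nc3cn2)c(F)c1` also gives only a limit in this assay, < 5000 nM. The steps among them, a step that the two limits leave unreadable from compound 1 to compound 2, a step that the two limits leave unreadable from compound 1 to compound 3 and a step that the two limits leave unreadable from compound 2 to compound 3, cannot be read in size or direction, because of the limit of < 5000 nM in this assay, at which 3 of the 3 values shown sit.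

Compound 4 `N#Cc1ccc(Nc2cc3[nH]c(-c4cccc(C(F)(F)F)c4)nc3cn2)nc1` has not yet been measured in this assay. It differs from compound 1 in one place: 5-cyanopyridin-2-yl in place of 6-methoxypyridin-2-yl on a nitrogen on an aromatic ring. The measured steps that bear on this change are the three unreadable ones above, each an exchange of the group on the same nitrogen, so neither a size nor a direction of step can be drawn from them, and nothing beyond the scatter can be predicted with confidence. The measurement for compound 4 in this assay is expected, most likely, to be reported again as a limit rather than a number. Should a number be returned, the estimate for compound 4 is 2000 nM, with a range from 500 nM to 6000 nM. This corresponds to an expected step that the limit leaves unreadable from compound 1 to compound 4.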

Compound 4, solubility: < 5000 nM
Compound 4: only a limit was reported; the forecaster's own chance of this, stated with the estimate: 85%; the middle value is on the limit's open side.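

Compound 4 also gives only a limit in this assay, < 5000 nM. Among the compounds shown here, no step from compound 1, compound 2 or compound 3 to compound 4 can therefore be read in size or direction, because the values share one limit: the limit of < 5000 nM in this assay, at which 4 of the 4 values shown sit. The compounds shown leave open how the four compare in solubility, and whether exchanging the group on this nitrogen changes it at all.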